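The source may report more compounds than this note shows. Statements on the series, on what has been measured and on what is new or still open speak of the compounds shown alone.

In an assay on HEK293 cells for activation of Kir3.1/Kir3.2 (Homo sapiens), read by thallium flux (a lower number here means a smaller maximal response, a higher number a larger maximal response), compound 3 `Cc1cc(NC(=O)Cn2nnc(-c3cccnc3)n2)n(C2CCCCC2)n1` reaches 96%, the higher of the two numbers that are reported as numbers. Compound 1 `Cc1cc(NC(=O)Cn2nnc(-c3ccccc3)n2)n(C2CCS(=O)(=O)C2)n1` gives 93%, a value that falls within the usual scatter of the value of compound 3, so the two cannot be told apart. Compound 2 `CC1(c2cc(NC(=O)Cn3nnc(-c4ccccc4)n3)n(C3CCCCC3)n2)CC1` yields only a limit of the assay, > 10%; this is the single case of the limit of > 10% in this assay, at which 1 of the 3 values shown sits. The untested compound 4 `Cc1cc(NC(=O)Cn2nnc(-c3ccccc3F)n2)n(C2CCCCC2)n1` differs from compound 3 in one place: 2-fluorophenyl in place of pyridin-3-yl on an aromatic carbon. For the measured compounds named here, no measured pair shows this exchange, so its effect is open. Compound 1 with 93% and compound 3 with 96% both reach a large response in this assay. On that basis the step of a number 6 percentage points lower from compound 3 to compound 4 (within the scatter) is expected to stay within the scatter. Compound 4 is therefore estimated at 90%, between 70% and 102%.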

Compound 4, largest response reached (Emax), in percent of the reference or control that the assay uses: 88%
Compound 4: middle estimate off by 2 percentage points, on the high side; the range from low to high includes it.
By their numbers in this assay, from the lowest: compounds 4, 1 and 3 (each within the scatter of the next).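

On the aromatic carbon between two ring nitrogen atoms, replacing pyridin-3-yl with 2-fluorophenyl gives a number 8 percentage points lower from compound 3 to compound 4 (within the scatter) in this assay. This position therefore accepts a carbon-only aromatic ring bearing fluorine in place of a ring with a hetero atom, and the pyridine nitrogen is not needed for a large maximal response in this pair. Nothing shown explains this tolerance. Going by these compounds, it remains open whether a non-aromatic group, such as a cyclohexyl ring or a longer alkyl chain, would hold the response at this carbon. On these data alone, an aminomethyl or carboxylic acid substituent on the phenyl ring is equally open.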